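A few compounds are considered here, and "the series" means these few. Any claim that something is new, unique, unknown or untested is made for them only; others in the source may bear on it.

Three compounds sharing one core, each carrying a different group on a carbonyl carbon, have been measured in a functional assay on BGC-823 cells (Homo sapiens) for cytotoxicity, read by MTT assay, with a stated time of 72 h; on this read-out higher numbers stand for weaker inhibition and lower numbers for stronger inhibition. Compound 1 `CN1[C@@H]2c3[nH]c4ccccc4c3C[C@H]1[C@H](C#N)N1[C@@H](CNC(=O)c3cccc(C(F)(F)F)c3)c3[nH]c4ccccc4c3C[C@@H]21` gives 870 nM. Compound 2 `COc1ccc(C(=O)NC[C@H]2c3[nH]c4ccccc4c3C[C@H]3[C@H]4c5[nH]c6ccccc6c5C[C@@H]([C@H](C#N)N23)N4C)cc1` gives 320 nM. Compound 3 `CCc1ccc(C(=O)NC[C@H]2c3[nH]c4ccccc4c3C[C@H]3[C@H]4c5[nH]c6ccccc6c5C[C@@H]([C@H](C#N)N23)N4C)cc1` gives 660 nM. Among these three numbers compound 3 holds the second highest; its gap to compound 1 lies within the usual scatter, while its gap to compound 2 is the larger one, a step of a 2.1-fold higher number from compound 2 to compound 3 (0.31 log units; beyond the scatter).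

Compound 4 `CN1[C@@H]2c3[nH]c4ccccc4c3C[C@H]1[C@H](C#N)N1[C@@H](CNC(=O)c3cccc4c3CCCC4)c3[nH]c4ccccc4c3C[C@@H]21` differs from compound 3 at that same carbonyl carbon: 1,2,3,4-tetrahydronaphthalen-5-yl in place of 4-ethylphenyl on a carbonyl carbon. The earlier exchanges at this position moved the numbers only modestly: a 2.7-fold lower number from compound 1 to compound 2 (0.43 log units; beyond the scatter), a 1.3-fold lower number from compound 1 to compound 3 (0.12 log units; within the scatter) and a 2.1-fold higher number from compound 2 to compound 3 (0.31 log units; beyond the scatter). Among the compounds with values here, none of those swaps, however, introduced a second ring fused to the aromatic ring, so the new group has no direct precedent here. Since every group tried so far at this carbonyl carbon landed within a narrow band, the step of a 1.0-fold lower number from compound 3 to compound 4 (0.01 log units; within the scatter) is expected to stay within or only just beyond the scatter, with no preferred direction. Compound 4 is therefore estimated at 650 nM in this assay, with a likely range of 250 nM to 1700 nM.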

Compound 4, half-maximal inhibitory concentration: 3540 nM
Estimate against measurement, compound 4: 5.4-fold (0.74 log units) below; the whole stated range lies below it.
By their numbers in this assay, from the lowest: compound 2; then compounds 3 and 1 (each within the scatter of the next); then compound 4.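

At this carbonyl carbon, the 1,2,3,4-tetrahydronaphthalen-5-yl group gives the first large loss of activity in this assay and makes compound 4 the weakest of the four, with a 5.4-fold higher number from compound 3 to compound 4 (0.73 log units; beyond the scatter) and a 4.1-fold higher number from compound 1 to compound 4 (0.61 log units; beyond the scatter) as well as the widest gap at this position, an 11-fold higher number from compound 2 to compound 4 (1.04 log units; beyond the scatter). The position therefore does not tolerate every carbon-only aryl group equally, although the three earlier groups stayed much closer together. The entering group adds a non-aromatic ring and two heavy atoms but leaves the hydrogen-bond donor and acceptor counts at zero, so those counts do not separate compound 3 from compound 4, and no measurement here explains the loss.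

The compounds shown cannot say whether the added ring itself or the different way the aromatic ring is substituted matters more. A plain phenyl group or a fully aromatic naphthalen-1-yl group on the same carbonyl carbon would help pull these two apart.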